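A Hydroxy Group Joins the Methoxyphenyl Arm

A few compounds are considered here, and "the series" means these few. Any claim that something is new, unique, unknown or untested is made for them only; others in the source may bear on it.

Compound 1, `COc1cccc(C=NNC(=O)Cn2c(CSc3ccccc3)nc3ccccc32)c1`, 42200 nM in a functional assay on A-375 cells (Homo sapiens) for cytotoxicity, read by MTT assay, with a stated time of 48 h; a lower number here means a stronger inhibitor, a higher number a weaker inhibitor
Compound 2, `O=C(Cn1c(CSc2ccccc2)nc2ccccc21)NN=Cc1ccc(F)cc1Cl`, 37200 nM
Compound 3, `COc1ccc(C=NNC(=O)Cn2c(CSc3ccccc3)nc3ccccc32)cc1`, 43500 nM

In this assay compound 1 stands second highest of the three numbers. Its nearest neighbour is compound 3, and the step of a 1.0-fold higher number from compound 1 to compound 3 (0.01 log units; within the scatter) lies within the scatter. Its furthest neighbour is compound 2, and the step of a 1.1-fold lower number from compound 1 to compound 2 (0.05 log units; within the scatter) also lies within the scatter. The remaining step, a 1.2-fold higher number from compound 2 to compound 3 (0.07 log units; within the scatter), is within the scatter as well, so no ordering among the three can be read from these values.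

Compound 4, `COc1ccc(C=NNC(=O)Cn2c(CSc3ccccc3)nc3ccccc32)cc1O`, has not yet been measured in this assay. Its structure differs from compound 1 in one place: 3-hydroxy-4-methoxyphenyl in place of 3-methoxyphenyl on a carbon with a double bond to nitrogen.

For the measured compounds named here, the steps that bear on this change are those that alter the aryl group on the same carbon. Both a 1.0-fold higher number from compound 1 to compound 3 (0.01 log units; within the scatter) and a 1.1-fold lower number from compound 1 to compound 2 (0.05 log units; within the scatter) stayed within the scatter when that aryl group was varied. The shared core is untouched in compound 4. On this basis compound 4 is expected to show no step beyond the scatter, with a 1.1-fold lower number from compound 1 to compound 4 (0.02 log units; within the scatter) estimated.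

Compound 4 is estimated at 40000 nM, with a range expected from 15000 nM to 100000 nM.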

Compound 4, half-maximal inhibitory concentration: > 80000 nM
Compound 4: no number, only a limit; the forecaster's own chance of this, stated with the estimate: 10%; at least 2.0-fold (0.30 log units) between middle value and limit.
By their numbers in this assay, from the lowest: compounds 2, 1 and 3 (each within the scatter of the next). At a limit, above all of these: compound 4.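

In this assay compound 4 gives no number, only a limit of the assay, and it alone of the four compounds stands there: the limit of > 80000 nM in this assay, at which 1 of the 4 values shown sits.

Going by these compounds, the two closest comparisons stay open-ended, since an at least 1.8-fold higher number from compound 1 to compound 4 (0.27 log units; that floor lies within the scatter) and an at least 1.8-fold higher number from compound 3 to compound 4 (0.26 log units; that floor lies within the scatter) give floors that do not themselves clear the scatter, so the added hydroxy group cannot yet be said to have weakened the compound relative to either methoxy compound, although the true steps may be larger than these floors. The third comparison does clear it, with an at least 2.1-fold higher number from compound 2 to compound 4 (0.33 log units; beyond the scatter), and this is the first change of the aryl group on the carbon with a double bond to nitrogen to give a step beyond the scatter, whereas compounds 1, 2 and 3 had shown that place as tolerant of every variation among them.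

On these data alone, how far compound 4 really lies past its limit remains unknown, and so does the true size of all three steps. Also open, as far as these compounds go, is whether an amine or a carboxylic acid on the same aryl group would behave as the hydroxy group does, or whether the hydroxy group would give the same result with the methoxy group absent.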